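Cytotoxicity on endothelial cells: oxime ether series, fluoro analogue

The source may hold more compounds than are shown below. What is called first, only, known or untested is meant among the compounds shown, and "the series" means these compounds.

Measured so far in an ADME assay on HUVEC cells (Homo sapiens) for cytotoxicity, read by MTT assay, with a stated time of 2 days; a higher number here means a weaker inhibitor, a lower number a stronger inhibitor:
compound 1, `O=[N+]([O-])c1ccc2c(c1)/C(=N\O)C(c1c[nH]c3ccc([N+](=O)[O-])cc13)=N2`, > 100000 nM
compound 2, `c1ccc(CO/N=C2/C(c3c[nH]c4ccccc34)=Nc3ccccc32)cc1`, > 100000 nM
compound 3, `Cc1ccc(CO/N=C2/C(c3c[nH]c4ccc(Br)cc34)=Nc3ccc(Br)cc32)cc1`, > 100000 nM

Each of these readings is a limit of this assay and not a number. For compound 2 the value > 100000 nM in this assay is such a limit. Compound 2 therefore cannot be placed on a scale relative to compound 1 or compound 3; all three sit at the same limit, as stated in the limit of > 100000 nM in this assay, at which 3 of the 3 values shown sit, and no ordering among them can be read.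

Compound 4, `Fc1ccc(CO/N=C2/C(c3c[nH]c4ccccc34)=Nc3ccccc32)cc1`, is still to be measured in this assay. It differs from compound 2 in one place: fluoro in place of hydrogen on an aromatic carbon, which reads as benzyloxy to (4-fluorobenzyl)oxy. Within the data shown here, no step between measured compounds is available to anchor the size of this change. With the three measured compounds all at the limit, no movement beyond the scatter is expected, and the most likely outcome is expected to be another limit reading. The step from compound 2 to compound 4 is estimated as a step that the limit leaves unreadable from compound 2 to compound 4. Compound 4 is expected to give 150000 nM, within 50000 nM to 500000 nM, in this assay.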

Compound 4, half-maximal inhibitory concentration: > 100000 nM
Compound 4: no number, only a limit; the forecaster's own chance of this, stated with the estimate: 85%; the middle value does not contradict the limit.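

In this assay compound 4 gives > 100000 nM, a limit of the assay and not a number. Among these compounds, compound 2 also reads as a limit, so no step between compound 2 and compound 4 can be read. The compounds shown leave open what fluoro in place of hydrogen does to a numerical reading in this assay.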